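Ethyl in Place of Methyl on the Piperazine of Compound 3

This account rests on a few compounds, and the source may have more. Where it says the series, first, only, none or still open, it means among the compounds named here.

Compound 3 `CNc1ncc2c(-c3ccc(N4CCN(C)CC4)nc3)nn(Cc3cn(Cc4ccccc4)nn3)c2n1` is one of three measured compounds that share a single core. In an assay for inhibition of tyrosine-protein kinase receptor TYRO3 (Homo sapiens), read by 33P incorporation, in the presence of a further agent that is not named here (a lower number here means a stronger inhibitor, a higher number a weaker inhibitor), compound 3 gives > 10000 nM, which is a limit of the assay rather than a number. Compound 1 `CNc1ncc2c(-c3ccc(N4CCNCC4)nc3)nn(Cc3cn(Cc4ccccc4)nn3)c2n1` likewise gives only a limit, > 10000 nM. Compound 2 `CNc1ncc2c(-c3ccc(N4CCNCC4)cc3)nn(Cc3cn(Cc4ccccc4)nn3)c2n1` also gives a limit, > 10000 nM. The steps a step that the two limits leave unreadable from compound 1 to compound 2 and a step that the two limits leave unreadable from compound 1 to compound 3 remain unreadable because of the limit of > 10000 nM in this assay, at which 3 of the 3 values shown sit. Compound 4 `CCN1CCN(c2ccc(-c3nn(Cc4cn(Cc5ccccc5)nn4)c4nc(NC)ncc34)cn2)CC1` differs from compound 3 by methyl in place of hydrogen on a saturated chain carbon bound to an amine nitrogen in a ring. Going by the values given here, no measured step bears on this change, and every value shown is a limit. Compound 4 is therefore expected to stay at the limit, with an estimated step that the limit leaves unreadable from compound 3 to compound 4 of none beyond the scatter. Compound 4 is estimated at 15000 nM, within 5000 nM to 50000 nM.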

Compound 4, half-maximal inhibitory concentration: 1900 nM
Estimate against measurement, compound 4: 7.9-fold (0.90 log units) above, and the stated range ends above it.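

In this assay, going by these compounds alone, the 4-ethylpiperazin-1-yl group gives the only readable number among the compounds on the shared core, with an at least 5.2-fold lower number from compound 3 to compound 4 (0.72 log units; beyond the scatter) when it replaces 4-methylpiperazin-1-yl. The comparison with the unsubstituted piperazine gives an at least 5.2-fold lower number from compound 1 to compound 4 (0.72 log units; beyond the scatter), so the group on this amine nitrogen in a ring can move the reading off the limit. The other steps cannot be read, and the true size of these two stays unknown because of the limit: the limit of > 10000 nM in this assay, at which 3 of the 4 values shown sit.

Going by these compounds, whether a longer chain such as propyl, or a cyclopropyl ring, on this nitrogen would lower the number further remains open. Also open, on these data alone, is whether ethyl would have the same effect on the 4-(piperazin-1-yl)phenyl compound.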